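A few compounds are considered here, and "the series" means these few. Any claim that something is new, unique, unknown or untested is made for them only; others in the source may bear on it.

Within the data shown here, compound 1 `CC(C)(C)C1=NN(c2cccc(Cl)c2)C(c2ccc(O)cc2)C1` is the only compound here with a number: in an assay on isolated protein for inhibition of protein kinase C zeta type (Homo sapiens), with a stated time of 4 min (a lower number here means a stronger inhibitor, a higher number a weaker inhibitor), compound 1 gives 5200 nM, which marks it as a weak inhibitor. A second compound, compound 2 `CC(C)(C)C1=NN(c2c(Cl)cccc2Cl)C(c2ccc(O)cc2)C1`, has in this assay only the entry "not determined" (no result reported), so no result is reported for it. Compound 3 `Oc1ccc(C2CC(c3ccccn3)=NN2c2cccc(Cl)c2)cc1` differs from compound 1 by pyridin-2-yl in place of tert-butyl on a carbon with a double bond to nitrogen. Among the measured compounds shown here, no measured pair shows what such a swap does here, so the expected change in this assay is small, in no clear direction, and within the usual scatter. Compound 3 is therefore estimated at 4000 nM, with a likely range from 1000 nM to 16000 nM. That estimate for compound 3 amounts to a 1.3-fold lower number from compound 1 to compound 3 (0.11 log units; within the scatter).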

Compound 3, half-maximal inhibitory concentration: 6200 nM
Compound 3: the middle estimate sits 1.6-fold (0.19 log units) below what was measured; the measured number falls inside the stated range.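

In this assay, among these compounds, the swap of tert-butyl for pyridin-2-yl gives a 1.2-fold higher number from compound 1 to compound 3 (0.08 log units; within the scatter) and so shows something the earlier compounds could not: on this carbon with a double bond to nitrogen, a branched carbon group and a six-membered aromatic ring with a ring nitrogen read alike. No measured evidence is available to explain this result. A single swap shows only these two groups, so it says little about the position as a whole. On these data alone, how an amine, a carboxylic acid or a plain phenyl ring would read on this carbon remains open.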